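The compounds below may be only part of what the source reports. "The series", "measured", "known", "first", "only" and "open" are said of these compounds alone.

Measured so far:

Compound 1, `C=C1[C@@H](C/C=C2/C(=O)OC[C@H]2OC(C)=O)[C@]2(C)CC[C@@H](OC(C)=O)[C@@](C)(CO[Si](C)(C)C(C)(C)C)[C@H]2C[C@@H]1O`, gives 6960 nM in a functional assay on MCF7 cells (Homo sapiens) for cytotoxicity, read by sulforhodamine B assay; on this read-out lower numbers stand for stronger inhibition and higher numbers for weaker inhibition.
Compound 2, `C=C1[C@@H](OC(C)=O)C[C@@H]2[C@](C)(COC=O)[C@H](OC(C)=O)CC[C@@]2(C)[C@@H]1C[C@@H](Nc1ccc(Br)cc1)C1=CCOC1=O`, gives 11400 nM in this assay.
Compound 3, `C=C1[C@@H](OC(C)=O)C[C@@H]2[C@](C)(CO[Si](C)(C)C(C)(C)C)[C@H](OC(C)=O)CC[C@@]2(C)[C@@H]1C[C@@H](Nc1ccc(OC)cc1)C1=CCOC1=O`, gives 4280 nM in this assay.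

Among these three numbers, compound 2 carries the highest one. Its nearest neighbour is compound 1, whose number sits within the usual scatter of repeated measurements, so the two cannot be told apart. Compound 3 is the furthest away, with a number that lies beyond the scatter, so compound 3 does show stronger inhibition than compound 2; compound 3 also differs from compound 2 in more than one place, so no single step can be read from that pair.

Compound 4, `C=C1[C@@H](OC(C)=O)C[C@@H]2[C@](C)(COC=O)[C@H](OC(C)=O)CC[C@@]2(C)[C@@H]1C[C@@H](Nc1ccc(OC)c(OC)c1)C1=CCOC1=O`, has not yet been measured. It differs from compound 2 in one place: 3,4-dimethoxyphenyl in place of 4-bromophenyl on an amine nitrogen. Among the compounds with values here, no pair of measured compounds shows this change on its own, so there is no direct guide to its effect. The most that can be said is that the measured numbers all sit within a fairly narrow band, and the expected step from compound 2 to compound 4 in this assay is therefore small, a 1.6-fold lower number from compound 2 to compound 4 (0.21 log units; within the scatter), leaning toward a slightly lower number but not clearly beyond the scatter. On this basis compound 4 is estimated at 7000 nM, with a likely range from 2500 nM to 18000 nM.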

Compound 4, half-maximal inhibitory concentration: > 50000 nM
Compound 4: only a limit was reported; the forecaster's own chance of this, stated with the estimate: 10%; at least 7.1-fold (0.85 log units) between middle value and limit.
By their numbers in this assay, from the lowest: compounds 3, 1 and 2 (each within the scatter of the next, the first and the last beyond it). At a limit, above all of these: compound 4.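

Within the data shown here, this is the first single change that can be read in this assay: replacing 4-bromophenyl with 3,4-dimethoxyphenyl on the amine nitrogen gives an at least 4.3-fold higher number from compound 2 to compound 4 (0.64 log units; beyond the scatter) and so weakens inhibition. Among these compounds, no two of the earlier compounds differ in one place, so only now is it clear that the group on this nitrogen can change the result beyond the scatter. Going by these compounds, compound 4 has only a limit of the assay, so the full size of the step is unknown: the limit of > 50000 nM in this assay, at which 1 of the 4 values shown sits.

The swap removes the bromine and adds two methoxy groups at once, and the other comparisons with compound 3 or compound 1 cannot be read as single steps. On these data alone, it remains open how phenyl, 4-chlorophenyl or 3-methoxyphenyl on this nitrogen, on the core of compound 2, would behave.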